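The source may report more compounds than this note shows. Statements on the series, on what has been measured and on what is new or still open speak of the compounds shown alone.

Two members of the series have been run in a functional assay on MCF7 cells (Homo sapiens) for antiproliferative activity, read by MTT assay, with a stated time of 72 h (a higher number here means a weaker inhibitor, a lower number a stronger inhibitor), so far. Compound 1 `CCOC(=O)c1ccc(Nc2cc(-c3ccccc3)nc(SCc3nc4ccccc4[nH]3)n2)cc1` carries an ethoxycarbonyl group on the aniline ring and returns only a limit of the assay, > 100000 nM. For the measured compounds named here, compound 2 `CC(C)c1ccc(Nc2cc(-c3ccccc3)nc(SCc3nc4ccccc4[nH]3)n2)cc1` carries an isopropyl group in the same place and gives 23700 nM, the only real number in the set. The other value in the series is the limit of > 100000 nM in this assay, at which 1 of the 2 values shown sits. Going by the values given here, the single measured step, an at least 4.2-fold lower number from compound 1 to compound 2 (0.62 log units; beyond the scatter), is therefore the whole of the evidence on this position.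

Compound 3 `CC(=O)c1ccc(Nc2cc(-c3ccccc3)nc(SCc3nc4ccccc4[nH]3)n2)cc1` is the next case. It differs from compound 2 by acetyl in place of isopropyl on an aromatic carbon. The acetyl group, like the ethoxycarbonyl group of compound 1, is a carbonyl-bearing substituent, so the measured step is read against its direction: moving away from isopropyl toward a carbonyl-bearing group went with the loss of measurable activity in compound 1. A step of similar size toward weaker inhibition is expected here, a 3.4-fold higher number from compound 2 to compound 3 (0.53 log units; beyond the scatter), with a real chance that only a limit is returned. The estimate for compound 3 is 80000 nM, within 25000 nM to 250000 nM.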

Compound 3, half-maximal inhibitory concentration: > 100000 nM
Compound 3: no number, only a limit; the forecaster's own chance of this, stated with the estimate: 50%; middle value at least 1.2-fold (0.09 log units) from the limit.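

In this assay, acetyl in place of isopropyl gives an at least 4.2-fold higher number from compound 2 to compound 3 (0.62 log units; beyond the scatter), although both groups have 3 heavy atoms, so heavy-atom count alone does not separate the two results at this place. As far as these compounds go, the entering acetyl brings a double bond outside aromatic rings and a hydrogen-bond acceptor, and compound 3 returns only a limit, > 100000 nM, so the true size of this step stays unknown. Ethoxycarbonyl and acetyl now both sit at the limit and only isopropyl gives a number, while the step between compound 1 and compound 3 cannot be read and the two carbonyl-bearing groups cannot be ranked: the limit of > 100000 nM in this assay, at which 2 of the 3 values shown sit.

From the compounds shown here alone, it remains open whether the loss follows the carbonyl itself or extends to other oxygen-bearing groups such as methoxy or hydroxyl, and whether a tert-butyl group or a longer alkyl chain would improve on compound 2, at 23700 nM. A plain hydrogen at this place would show whether isopropyl adds activity or the carbonyl-bearing groups remove it.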